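Restoring the amide hydrogen on a kinase inhibitor scaffold

This account rests on a few compounds, and the source may have more. Where it says the series, first, only, none or still open, it means among the compounds named here.

Measured compounds:
compound 1, `Cn1cc(CNS(=O)(=O)c2ccccc2Nc2cc(-c3ccc4ccn(C)c4c3)c3nccnc3c2)cn1`, 38 nM
compound 2, `CNC(=O)c1ccncc1Nc1cc(-c2ccc3ccn(C)c3c2)c2nccnc2c1`, 83 nM
compound 3, `CN(C)C(=O)c1ccncc1Nc1cc(-c2ccc3ccn(C)c3c2)c2nccnc2c1`, 499 nM

In an assay for inhibition of 6-phosphofructo-2-kinase/fructose-2,6-bisphosphatase 3 (Homo sapiens), read by ADP-Glo, with a stated time of 2 h (on this read-out higher numbers stand for weaker inhibition and lower numbers for stronger inhibition), compound 3 gives the highest of the three numbers; its nearest neighbour is compound 2, and compound 1 lies furthest away. Among the measured compounds shown here, the one single-point step among the measured compounds is a 6.0-fold higher number from compound 2 to compound 3 (0.78 log units; beyond the scatter), which shows that placing a methyl on the amide nitrogen, and so removing the amide hydrogen, raised the number well beyond the scatter.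

Compound 4, `Cn1ccc2ccc(-c3cc(Nc4cnccc4C(=O)NCc4cncnc4)cc4nccnc34)cc21`, is reached from compound 3 by ((pyrimidin-5-yl)methyl)amino in place of dimethylamino on a carbonyl carbon. This change brings back a hydrogen on the amide nitrogen, the same feature that separates compound 2 from compound 3, while adding a larger group than either. Because a 6.0-fold higher number from compound 2 to compound 3 (0.78 log units; beyond the scatter) was seen when the hydrogen was removed, a step back down in this assay is expected, of a size near that step, giving a 4.2-fold lower number from compound 3 to compound 4 (0.62 log units; beyond the scatter). Whether the added ring shifts the number further is not shown by any measured pair, so the estimate for compound 4 in this assay is 120 nM, within 40 nM to 350 nM.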

Compound 4, half-maximal inhibitory concentration: 106 nM
Compound 4: middle estimate off by 1.1-fold (0.05 log units), on the high side; measured number inside the range.
By their numbers in this assay, from the lowest: compound 1; then compounds 2 and 4 (each within the scatter of the next); then compound 3.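

In this assay, ((pyrimidin-5-yl)methyl)amino in place of dimethylamino on the carbonyl carbon gives a 4.7-fold lower number from compound 3 to compound 4 (0.67 log units; beyond the scatter), so a low number returns here with a group much larger than a methyl, provided the amide nitrogen again carries a hydrogen. Adding the pyrimidin-5-yl ring to the methyl of the simpler amide gives a 1.3-fold higher number from compound 2 to compound 4 (0.11 log units; within the scatter), which shows that, in this pair, the position accepts the ring with no readable change. Nothing in the data explains these numbers.

The compounds shown leave open whether this tolerance extends to other groups on the same chain carbon, such as a plain phenyl ring, a carboxylic acid or an amine. They also do not show whether a longer chain between the amide nitrogen and the ring would leave the number unchanged.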